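The source may report more compounds than this note shows. Statements on the series, on what has been measured and on what is new or still open speak of the compounds shown alone.

Measured so far in a physicochemical assay for lipophilicity, read by HPLC, at pH 3.0; a lower number here means a more polar compound, a higher number a more lipophilic compound:
Compound 1 `NCc1csc(NC(=O)c2ccc(Cl)cc2)n1` gives 1.2.
Compound 2 `NCc1csc(NC(=O)c2cnn[nH]2)n1` gives -0.2.
Compound 3 `CC(C)(C)c1cc(C(=O)Nc2ccccc2)n(Cc2ccccc2)n1` gives 4.7.

Compound 3 stands highest of the three numbers. Its nearest neighbour is compound 1, which gives 1.2, a number well below it and beyond the usual scatter. Further away lies compound 2, which gives -0.2, also beyond the scatter. No pair among these three differs in a single place, so the gaps between them say only how far apart the numbers lie, not what any one change is worth.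

Compound 4 `CC(C)(C)c1cc(C(=O)Nc2nc(CO)cs2)n(Cc2ccccc2)n1` has not yet been measured. It differs from compound 3 in one place: 4-(hydroxymethyl)-1,3-thiazol-2-yl in place of phenyl on an amide-type nitrogen. For the measured compounds named here, no step between measured compounds covers this change, so its size cannot be read off and must be estimated. The expectation is a downward step in this assay that clearly exceeds the scatter, estimated as a number 1.60 log units lower from compound 3 to compound 4 (beyond the scatter). On that basis compound 4 is expected at 3.1, within a range from 2.4 to 3.8.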

Compound 4, distribution coefficient: 3.5
Beside the measured number, compound 4's estimate is 0.40 log units below it; the range from low to high includes it.
By their numbers in this assay, from the lowest: compound 2; then compound 1; then compound 4; then compound 3.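

In this assay, for the compounds shown here, 4-(hydroxymethyl)-1,3-thiazol-2-yl in place of phenyl on the amide-type nitrogen gives a number 1.20 log units lower from compound 3 to compound 4 (beyond the scatter) and is the first change here that can be read in a single place with the rest of the molecule held constant. Going by these compounds alone, the earlier compounds differed from one another in more than one place, so only this pair shows that the group on this nitrogen can move the number by a large step, beyond the scatter. Nothing shown here accounts for the size of that step.

From the compounds shown here alone, how that step divides between the ring and its hydroxymethyl remains open, and an unsubstituted 1,3-thiazol-2-yl on this nitrogen would separate the two shares. Also open, going by these compounds, is how the number would move with an aminomethyl group, a carboxylic acid or a longer chain in place of the hydroxymethyl.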